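This account rests on a few compounds, and the source may have more. Where it says the series, first, only, none or still open, it means among the compounds named here.

Of the compounds shown here, three have so far been measured in a functional assay on the whole organism with Rattus norvegicus as the target, at a dose of 40 mg/kg by the intraperitoneal route; on this read-out higher numbers stand for more inhibition at the one dose given (going by the name of the read-out) and lower numbers for less inhibition. Compound 1, `Cc1nc2cc(CCc3ccccc3)ccn2c1N`, gives 50%. Compound 2, `Cc1nc2c(OCc3ccccc3)cccn2c1/N=C/N(C)C`, gives 64%, and compound 3, `CCNc1c(C)nc2c(CCc3ccccc3)cccn12`, gives 78%. Compound 2 thus stands second highest of the three: its number lies above that of compound 1 and below that of compound 3, and both gaps are beyond the usual scatter of repeated measurements, so the three values are genuinely distinct. Among the measured compounds shown here, no pair of these measured compounds differs in only a single place, so no isolated step can be read off from them.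

Compound 4, `CCCN(CCC)c1c(C)nc2c(OCc3ccccc3)cccn12`, has not yet been measured. It differs from compound 2 in one place: a group of 7 heavy atoms (6 carbon, 1 nitrogen; no ring) in place of a group of 5 heavy atoms (3 carbon, 2 nitrogen; no ring), on an aromatic carbon. The dipropylamino group enters on an aromatic carbon of a five-membered aromatic ring with 2 nitrogen, part of a fused or bridged system of two rings, where the leaving group stood. Nothing measured shows how this exchange alone moves the read-out, since compound 3 differs from compound 2 in more than one place. The expected step is a number 2 percentage points higher from compound 2 to compound 4 (within the scatter), which is taken to lie within the scatter. Compound 4 is therefore estimated at 66% in this assay, with a range from 48% to 84%.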

Compound 4, a percentage reported as inhibition, in the whole organism at one dose (the size of the read-out at that dose, not a potency): 60%
The estimate for compound 4 lay 6 percentage points above the measured number; measured number inside the range.
By their numbers in this assay, from the lowest: compounds 1, 4 and 2 (each within the scatter of the next, the first and the last beyond it); then compound 3.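

Among the compounds shown here, the exchange gives the first single-place comparison in this assay: a number 4 percentage points lower from compound 2 to compound 4 (within the scatter), and so compound 2 and compound 4 cannot be told apart on this read-out. At this position, on an aromatic carbon of the five-membered aromatic ring and next to the ring nitrogen, dipropylamino with its 7 heavy atoms takes the place of a group of 5 heavy atoms that has 1 double bond outside aromatic rings, and neither the larger group nor the loss of that double bond produces a separation beyond the scatter in this pair. Nothing measured on these groups accompanies this result, and nothing can be said about what lies behind it.

The compounds shown leave open how a morpholine ring or a dibutylamino group would read at this same place with the rest of compound 2 kept. Also open, on these data alone, is whether the step would hold on a core with a different side group, since compound 3 differs from compound 2 in more than one place and does not settle that.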